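The source may report more compounds than this note shows. Statements on the series, on what has been measured and on what is new or still open speak of the compounds shown alone.

In a functional assay on HL-60 cells (Homo sapiens) for antiproliferative activity, read by MTT assay, with a stated time of 72 h (a lower number here means a stronger inhibitor, a higher number a weaker inhibitor), compound 1 (`COc1ccc(OCCCON2C(N)=NC(N)=NC23CCOCC3)cc1`) gives 1670 nM and compound 2 (`NC1=NC2(CCOCC2)N(OCCCOc2ccc(Cl)c(Cl)c2)C(N)=N1`) gives 1240 nM on the same scale. Among the measured compounds shown here, these two numbers lie within the usual scatter of repeated measurements, so compound 2 stands level with the only other compound measured so far. Compound 3 (`NC1=NC2(CCOCC2)N(OCCCOc2cccc(Br)c2)C(N)=N1`) has not yet been measured. It carries 3-bromophenyl in place of 3,4-dichlorophenyl on an oxygen on a saturated carbon and keeps the rest of compound 2 unchanged.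

For the measured compounds named here, one measured step bears on this swap, as it alters the group at the same place. Putting 3,4-dichlorophenyl in place of 4-methoxyphenyl gave a 1.3-fold lower number from compound 1 to compound 2 (0.13 log units; within the scatter) and so stayed inside the scatter. A single step is thin evidence, but it offers no sign that this place responds strongly, so no shift beyond the scatter is expected in this assay in either direction. The estimated step is small (a 1.0-fold higher number from compound 2 to compound 3 (0.02 log units; within the scatter)). The expected value of compound 3 is 1300 nM (from 550 nM to 3000 nM).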

Compound 3, half-maximal inhibitory concentration: 560 nM
Estimate against measurement, compound 3: 2.3-fold (0.37 log units) above; measured number inside the range.
By their numbers in this assay, from the lowest: compound 3; then compounds 2 and 1 (each within the scatter of the next).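

In this assay, among the compounds shown here, the one earlier step at this place stayed inside the scatter and gave no sign that the group on an oxygen on a saturated carbon matters, but a 2.2-fold lower number from compound 2 to compound 3 (0.35 log units; beyond the scatter) shows that it can. The same holds against the other earlier group, with a 3.0-fold lower number from compound 1 to compound 3 (0.47 log units; beyond the scatter), so compound 3 stands apart from both compounds, while those two remain level with each other. Although the step is modest, the group at this place can shift antiproliferative activity on these cells even with the rest of the molecule unchanged, and nothing shown here explains why.

The swap from 3,4-dichlorophenyl to 3-bromophenyl changes both the kind of halogen and the number of halogen atoms at once, so these compounds cannot tell which of the two matters, or whether bromine is needed at all. A plain phenyl ring, a phenyl ring carrying a nitrile, or a longer chain leading to the ring would each test a different part of this question.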